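The compounds below may be only part of what the source reports. "The series", "measured", "known", "first", "only" and "open" are said of these compounds alone.

Going by the values given here, in a functional assay on HEL cells (Homo sapiens) for cytotoxicity (on this read-out lower numbers stand for higher toxicity in this test and higher numbers for lower toxicity in this test), compound 3 (`CCCCCCC#Cc1cc2cn([C@H]3C[C@H](O)[C@@H](CO)O3)c(=O)nc2o1`) gives 138000 nM, the only actual number among the three values available. Compound 2 (`CCCCCCC#Cc1cc2cn([C@@H]3O[C@H](CO)[C@@H](O)[C@H]3O)c(=O)nc2o1`) gives > 133000 nM, which is a limit. Compound 1 (`CCCCC#Cc1cc2cn(C)c(=O)nc2o1`) gives > 217000 nM, which is also a limit.

The next compound, compound 4 (`CCCCCCC#Cc1cc2cn(C)c(=O)nc2o1`), keeps the side chain of compound 3 and changes the group on an aromatic nitrogen: methyl in place of 4-hydroxy-5-(hydroxymethyl)oxolan-2-yl on an aromatic nitrogen.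

Among the compounds with values here, only one measured step touches this group, a step that the limit leaves unreadable from compound 2 to compound 3, and it gives no size to build on. Within the data shown here, compound 1 is the only measured compound that already has methyl on that nitrogen, though its side chain differs from that of compound 4. For compound 1, the value of > 217000 nM is a limit and shows no measurable toxicity in this assay.

Nothing measured therefore points to a large change, and the expectation is for little movement from compound 3 at 138000 nM. Any shift should lean towards higher numbers, meaning lower toxicity in this test. The expected size is a 1.2-fold higher number from compound 3 to compound 4 (0.09 log units; within the scatter), which would not go beyond the scatter. Compound 4 is estimated at 170000 nM, with an expected range from 70000 nM to 300000 nM.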

Compound 4, half-maximal cytotoxic concentration: > 194000 nM
Compound 4: no number, only a limit; the forecaster's own chance of this, stated with the estimate: 65%; middle value at least 1.1-fold (0.05 log units) from the limit.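

In this assay, going by these compounds alone, the change on the aromatic nitrogen gives an at least 1.4-fold higher number from compound 3 to compound 4 (0.14 log units; that floor lies within the scatter), the first step at this position with any readable size, though only its floor is known and the full size stays unknown. Losing the 4-hydroxy-5-(hydroxymethyl)oxolan-2-yl group for methyl therefore brought no lower number in this test, and with the side chain held constant, the only actual number in the series gives way to a limit of the assay: the limit of > 194000 nM in this assay, at which 1 of the 4 values shown sits. The steps from compound 2 and from compound 1 to compound 4 cannot be read, with limits at both ends.

From the compounds shown here alone, it remains open how far the true value of compound 4 lies from its limit, and so whether the change at this nitrogen moves the read-out beyond the scatter at all. Going by these compounds, it also remains open how an amine-bearing chain or a carboxylic acid on this nitrogen, or a longer chain on the triple-bonded carbon, would read in this assay.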